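Changing One Ring on an Inactive Amide

This account rests on a few compounds, and the source may have more. Where it says the series, first, only, none or still open, it means among the compounds named here.

Of the compounds shown here, two built on a shared core have been tested in a functional assay on KYSE-70 cells for antiproliferative activity against KYSE-70 cell line (Homo sapiens), read by MTT assay, with a stated time of 72 h; a lower number here means a stronger inhibitor, a higher number a weaker inhibitor. Compound 1 `O=C(c1cc(=O)[nH]c2cc(Br)ccc12)N1CCCCC1` gives > 20000 nM, which is a limit and not a number. Compound 2 `O=C(Nc1ccc(Cl)cc1)c1cc(=O)[nH]c2cc(Br)ccc12` gives > 20000 nM, which is also a limit. Compound 2 therefore stands at the limit of > 20000 nM in this assay, at which 2 of the 2 values shown sit, and no true potency has been read for it. Compound 3 `O=C(Nc1ccccn1)c1cc(=O)[nH]c2cc(Br)ccc12` keeps the shared core and changes only the group on the amide-type nitrogen: pyridin-2-yl in place of 4-chlorophenyl on an amide-type nitrogen. For the measured compounds named here, no measured step is available as a guide, so the expectation in this assay is no change beyond the scatter, in either direction, and another reading at the limit is the likeliest result. The estimated step is a step that the limit leaves unreadable from compound 2 to compound 3. For compound 3 the expected value is 22000 nM, with an estimated range of 10000 nM to 40000 nM.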

Compound 3, half-maximal inhibitory concentration: 11000 nM
Compound 3: the middle estimate sits 2.0-fold (0.30 log units) above what was measured; the measured number falls inside the stated range.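

In this assay compound 3 gives a readable number, whereas the other two compounds give only a limit: the limit of > 20000 nM in this assay, at which 2 of the 3 values shown sit. Placing pyridin-2-yl instead of 4-chlorophenyl on the amide-type nitrogen gives an at least 1.8-fold lower number from compound 2 to compound 3 (0.25 log units; that floor lies within the scatter), and placing (pyridin-2-yl)amino instead of piperidin-1-yl on the carbonyl carbon gives an at least 1.8-fold lower number from compound 1 to compound 3 (0.25 log units; that floor lies within the scatter). Both steps are floors, so the real gaps could be larger, but as printed neither goes beyond the scatter, and this position has so far shown only a weak inhibitor.

The change from compound 2 to compound 3 removes the chlorine and brings in a ring nitrogen at once, and these compounds do not tell which of the two matters. A plain phenyl group or a pyridin-4-yl group on the same nitrogen would help to separate the two.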